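The source may report more compounds than this note shows. Statements on the series, on what has been measured and on what is new or still open speak of the compounds shown alone.

In a functional assay on NCI-H441 cells (Homo sapiens) for antiproliferative activity, with a stated time of 24 h (on this read-out higher numbers stand for weaker inhibition and lower numbers for stronger inhibition), compound 1 `CN(C)c1ccc(/C=C2\CNC/C(=C\c3ccc(N(C)C)cc3)C2=O)cc1` gives 101000 nM, compound 2 `O=C(O)CCCC(=O)N1C/C(=C\c2ccccc2F)C(=O)/C(=C/c2ccccc2F)C1` gives 60000 nM and compound 3 `O=C1/C(=C/c2ccccc2F)CN(C(=O)c2ccccc2C(=O)O)C/C1=C\c1ccccc1F` gives 56000 nM. Compound 3 thus stands within the scatter of both other compounds. Compound 4 `Cc1ccc(S(=O)(=O)N2C/C(=C\c3ccccc3F)C(=O)/C(=C/c3ccccc3F)C2)cc1` differs from compound 3 by one change, ((4-methylphenyl)sulfonyl in place of (2-carboxyphenyl)carbonyl on an amine nitrogen in a ring). Among the measured compounds shown here, the only measured step that bears on it, a 1.1-fold lower number from compound 2 to compound 3 (0.03 log units; within the scatter), stayed within the scatter, but it swapped one carboxy-bearing group for another. For the measured compounds named here, no measured step removes the carboxy group from this shared core, so the evidence is thin. A modest move towards a lower number is expected, a 2.8-fold lower number from compound 3 to compound 4 (0.45 log units; beyond the scatter). For compound 4 the estimated value is 20000 nM, with an expected range from 4000 nM to 70000 nM.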

Compound 4, half-maximal inhibitory concentration: 50000 nM
Compound 4: middle estimate off by 2.5-fold (0.40 log units), on the low side; the measured number falls inside the stated range.
By their numbers in this assay, from the lowest: compounds 4, 3, 2 and 1 (each within the scatter of the next, the first and the last beyond it).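

Putting (4-methylphenyl)sulfonyl in place of (2-carboxyphenyl)carbonyl on the amine nitrogen in the ring leaves the number within the scatter (a 1.1-fold lower number from compound 3 to compound 4 (0.05 log units; within the scatter)), and the same holds against the (3-carboxypropyl)carbonyl group (a 1.2-fold lower number from compound 2 to compound 4 (0.08 log units; within the scatter)). The carboxylic acid carried by compound 2 and compound 3 is therefore not needed to keep the number at this level, since compound 4 has none. No measurement here explains why these three groups read alike. Still open, going by these compounds, is whether an amine-bearing chain or a small acetyl group on this nitrogen would move the number beyond the scatter.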